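This account rests on a few compounds, and the source may have more. Where it says the series, first, only, none or still open, it means among the compounds named here.

Among the measured compounds shown here, in a functional assay on HCT-116 cells (Homo sapiens) for cytotoxicity, read by MTT assay, with a stated time of 72 h (on this read-out higher numbers stand for weaker inhibition and lower numbers for stronger inhibition), compound 2 `N[C@H]1CC[C@H](Nc2c(C(=O)NCc3ccc(F)cc3)nc(Br)c3cccnc23)CC1` gives 4000 nM, the only actual number available so far. Compound 1 `N[C@H]1CC[C@H](Nc2c(C(=O)NCc3ccc(F)cc3)nc(N3CCCCS3(=O)=O)c3cccnc23)CC1` reaches only a limit, > 10000 nM. For the measured compounds named here, the single measured step, an at least 2.5-fold lower number from compound 1 to compound 2 (0.39 log units; beyond the scatter), swaps a larger group on an aromatic carbon for one bromine atom, and it is at least modest in size. That step rests on (the limit of > 10000 nM in this assay, at which 1 of the 2 values shown sits).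

Compound 3 `O=C(NCc1ccc(F)cc1)c1nc(Br)c2cccnc2c1NCc1ccccc1` keeps the bromine of compound 2 and differs at another place: benzyl in place of 4-aminocyclohexyl on a nitrogen on an aromatic ring. Going by the values given here, the measured step does not touch this nitrogen substituent, so it bears on the new change only indirectly, and no measured step gives its size or direction. With so little to go on, no clear shift is expected in this assay. The expected change, a 1.3-fold higher number from compound 2 to compound 3 (0.10 log units; within the scatter), is estimated to stay within the scatter, with no firm direction. For compound 3 the estimated value is 5000 nM, with an expected range of 1300 nM to 20000 nM.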

Compound 3, half-maximal inhibitory concentration: > 20000 nM
Compound 3 was reported as a limit (the forecaster's own chance of this, stated with the estimate: 30%); middle value at least 4.0-fold (0.60 log units) away from the limit.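

With the bromine held fixed, benzyl in place of 4-aminocyclohexyl on a nitrogen on an aromatic ring gives an at least 5.0-fold higher number from compound 2 to compound 3 (0.69 log units; beyond the scatter) in this assay, so the nitrogen substituent, which the earlier step left untouched, does change this read-out. Compound 3 gives > 20000 nM, which is a limit of the assay and not a number, so this step fixes the direction and a minimum size but not the full size: the limit of > 20000 nM in this assay, at which 1 of the 3 values shown sits. The two groups have the same heavy-atom count, so the step does not come from a change in that count; they differ in the ring, aromatic in benzyl and non-aromatic in 4-aminocyclohexyl, and in the amine nitrogen, and this one pair cannot separate those two differences.

On these data alone, it remains open whether the amine or the ring accounts for the step, a question that a plain cyclohexyl group or a benzyl group carrying an aminomethyl group on the same nitrogen would address. As far as these compounds go, it is also open whether the same substituent change would give a similar step with a group other than bromine on the aromatic carbon.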